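The source may hold more compounds than are shown below. What is called first, only, known or untested is meant among the compounds shown, and "the series" means these compounds.

Compound 1 `Cc1c(C)c2c(c(C)c1OC(=O)CCC(=O)O)CCC(C)(C(=O)NC1CC(C)(C)N([O])C(C)(C)C1)O2` gives > 300000 nM
Compound 2 `Cc1c(C)c2c(c(C)c1OC(=O)CCC(=O)NC1CC(C)(C)N([O])C1(C)C)CCC(C)(C(=O)NC1CC(C)(C)N([O])C1(C)C)O2` gives > 300000 nM

In a functional assay on CEM13 cells (Homo sapiens) for cytotoxicity, read by MTT assay, with a stated time of 72 h (on this read-out higher numbers stand for weaker inhibition and lower numbers for stronger inhibition), compound 2 gives > 300000 nM, which is a limit of the assay and not a number. Compound 1 also gives only a limit, > 300000 nM. Compound 3 `Cc1c(C)c2c(c(C)c1OC(=O)CCC(=O)O)CCC(C)(C(=O)NC1CC(C)(C)N([O])C1(C)C)O2` follows from compound 2 by one change on a carbonyl carbon, where hydroxy enters: one oxygen atom in place of a group of 11 heavy atoms (8 carbon, 2 nitrogen, 1 oxygen; one five-membered non-aromatic ring with 1 hetero atom), on a carbonyl carbon. No step beyond the scatter is expected in this assay, an expectation that rests on (the limit of > 300000 nM in this assay, at which 2 of the 2 values shown sit). The estimated change is a number no higher from compound 2 to compound 3 (the limit leaves the size open). Compound 3 is expected at about 300000 nM, within an estimated range of 100000 nM to 600000 nM.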

Compound 3, half-maximal inhibitory concentration: 205000 nM
Compound 3: middle estimate off by 1.5-fold (0.17 log units), on the high side, and the stated range covers the measured number.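

With hydroxy on the carbonyl carbon, compound 3 gives a readable number in this assay, and the change there amounts to an at least 1.4-fold lower number from compound 2 to compound 3 (0.16 log units; that floor lies within the scatter). The swap of the ring group on the amide-type nitrogen gives an at least 1.4-fold lower number from compound 1 to compound 3 (0.16 log units; that floor lies within the scatter). Both steps are floors that stay within the scatter, and their true size cannot be read: the limit of > 300000 nM in this assay, at which 2 of the 3 values shown sit.

As far as these compounds go, whether an amine or a methyl ester on that carbonyl carbon would shift the number in this assay stays open. So does the effect of a longer chain there.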